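This account rests on a few compounds, and the source may have more. Where it says the series, first, only, none or still open, it means among the compounds named here.

The measured compounds, each with its result in a toxicity assay on HepG2 cells (Homo sapiens) for inhibition, read by CellTiter-Glo, with a stated time of 48 h; a lower number here means a stronger inhibitor, a higher number a weaker inhibitor:

Compound 1, `CCC(Oc1cc(C)nc2ccc(OC)cc12)C(=O)Nc1cc(C)cc(C)c1`, gives 79400 nM in this assay.
Compound 2, `COc1ccc2nc(C)cc(OCC(=O)Nc3ccccc3)c2c1`, gives 39800 nM in this assay.
Compound 3, `COc1ccc2nc(C)cc(OCC(=O)Nc3cc(OC)c(Cl)cc3OC)c2c1`, reaches only the limit of > 100000 nM in this assay; this is a limit of the assay and not a number.

Among the two numbers that are not limits, compound 2 has the lowest one, and the nearest is compound 1, whose number lies within the scatter of repeated measurements, so no order between compound 2 and compound 1 can be claimed. The third value is only a limit, as the limit of > 100000 nM in this assay, at which 1 of the 3 values shown sits, records.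

Compound 4, `COc1ccc2nc(C)cc(OCC(=O)Nc3nccs3)c2c1`, has not yet been measured. It differs from compound 2 in one place: 1,3-thiazol-2-yl in place of phenyl on an amide-type nitrogen.

Going by the values given here, no step between two measured compounds is available to calibrate this change, so its size in this assay cannot be read off. All three measured compounds sit at weak inhibition, and compound 3 does not even give a number, so compound 4 is expected to remain in the same weak region. The step of a 1.4-fold higher number from compound 2 to compound 4 (0.14 log units; within the scatter) is estimated to be small, in the direction of a weaker inhibitor, and may not exceed the scatter. Compound 4 is therefore expected to give about 55000 nM, within a range from 20000 nM to 150000 nM.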

Compound 4, half-maximal inhibitory concentration: > 100000 nM
Compound 4: no number, only a limit; the forecaster's own chance of this, stated with the estimate: 35%; middle value at least 1.8-fold (0.25 log units) away from the limit.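

Going by these compounds alone, compound 2 and compound 4 give the first pair in this set that differs in one place, so a change at the amide-type nitrogen can now be sized in this assay: the result is an at least 2.5-fold higher number from compound 2 to compound 4 (0.40 log units; beyond the scatter). Within the data shown here, replacing phenyl with 1,3-thiazol-2-yl, with the rest of compound 2 held fixed, is therefore enough on its own to shift the read-out towards a weaker inhibitor by more than the scatter, which the earlier compounds could not show. The full size of this step stays unknown, since compound 4 yields a limit of the assay and not a number: the limit of > 100000 nM in this assay, at which 2 of the 4 values shown sit.

The compounds shown leave open whether this shift belongs to 1,3-thiazol-2-yl in particular or would also appear with another ring on the same nitrogen, such as a pyridin-2-yl or a furan-2-yl group, or with a phenyl carrying an amine or a carboxylic acid. They also leave open whether the same replacement would have a comparable effect on the core of compound 1, which carries a longer chain at the ether link and a dimethyl-substituted phenyl.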